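Sec-butyl for isobutyl on the amine nitrogen

The source may report more compounds than this note shows. Statements on the series, on what has been measured and on what is new or still open speak of the compounds shown alone.

Measured so far:
compound 1: `CC(C)CNC(=C\C(=O)/C=C/c1ccc(O)cc1)/C=C/c1ccc(O)cc1` — 82%
compound 2: `COc1cc(/C=C/C(=O)/C=C(/C=C/c2ccc(O)c(OC)c2)NC2CCCCC2)ccc1O` — 63%

In a functional assay on Caco-2 cells (Homo sapiens), read by fluorescence, tested at 10 uM (on this read-out higher numbers stand for a weaker effect at the one concentration tested and lower numbers for a stronger effect), compound 1 gives 82%, the highest of the two numbers available. Compound 2 gives 63%, a number lower by a margin that lies beyond the usual scatter of this read-out. Compound 2 differs from compound 1 in several places at once, so what the gap between the two values shows cannot be tied to any single change.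

Compound 3 is `CCC(C)NC(=C\C(=O)/C=C/c1ccc(O)cc1)/C=C/c1ccc(O)cc1`. It differs from compound 1 by sec-butyl in place of isobutyl on an amine nitrogen. The two compounds have the same atoms, joined differently; the group that leaves and the group that enters each carry no ring, no hydrogen-bond donor, no hydrogen-bond acceptor and no charge.

Among the compounds with values here, no step between measured compounds is at hand for this kind of change, so the expectation rests on the size of the change alone. Compound 3 is expected to read 80% in this assay, with a range from 65% to 95%. The step this estimate means, a number 2 percentage points lower from compound 1 to compound 3 (within the scatter), is expected to stay within the scatter, with no clear direction.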

Compound 3, a percentage reported as activity, at one concentration (the size of the read-out at that concentration, not a potency): 102%
For compound 3 the middle estimate is 22 percentage points below the measured one, and the stated range ends below it.
By their numbers in this assay, from the lowest: compound 2; then compound 1; then compound 3.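

The amine nitrogen is not a silent position in this assay: sec-butyl in place of isobutyl gives a number 20 percentage points higher from compound 1 to compound 3 (beyond the scatter), which on this read-out means a weaker effect at the one concentration tested. The two groups have the same count of carbon atoms and the same atoms overall, so in this pair, the way those carbons are joined is the only structural difference that goes with the change. The earlier pair could not give such a finding. Compound 2 differs from compound 1 in several places. No measured evidence at hand accounts for this step.

This is a single step at a single position, so it sets no trend for other groups on that nitrogen. Open questions are where an unbranched n-butyl chain or a tert-butyl group on the core of compound 1 would read in this assay, and whether the step from isobutyl to sec-butyl would hold on a core carrying the methoxy groups of compound 2.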